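A few compounds are considered here, and "the series" means these few. Any claim that something is new, unique, unknown or untested is made for them only; others in the source may bear on it.

Measured in a functional assay on DU-145 cells (Homo sapiens) for inhibition, read by trypan blue exclusion, with a stated time of 96 h; on this read-out lower numbers stand for stronger inhibition of growth and higher numbers for weaker inhibition of growth:
compound 1 `O=C(/C(=C\c1ccc(O)cc1O)SCc1ccc(Cl)cc1)c1ccc(Cl)cc1` gives 50000 nM
compound 2 `COc1ccccc1/C=C(/SCc1ccc(Cl)cc1)C(=O)c1ccc(Cl)cc1` gives 1000 nM
compound 3 `Cc1ccc(C)c(/C=C(/SCc2ccc(Cl)cc2)C(=O)c2ccc(Cl)cc2)c1` gives 10000 nM

Compound 1 carries the highest number of the three, so it is the weakest growth inhibitor in this set. Compound 4 `O=C(/C(=C\c1ccc(O)cc1O)Sc1ccccc1Br)c1ccc(Cl)cc1` keeps its 2,4-dihydroxyphenyl but has 2-bromophenyl in place of 4-chlorobenzyl on a sulfur. The measured steps, a 50-fold lower number from compound 1 to compound 2 (1.70 log units; beyond the scatter), a 5.0-fold lower number from compound 1 to compound 3 (0.70 log units; beyond the scatter) and a 10-fold higher number from compound 2 to compound 3 (1.00 log units; beyond the scatter), all change the group on a double-bonded chain carbon and leave the 4-chlorobenzyl untouched. For the measured compounds named here, no measured step covers a change on the sulfur, so they set no direction, and no step beyond the scatter is expected in this assay. The expected step is a 1.7-fold lower number from compound 1 to compound 4 (0.22 log units; within the scatter). For compound 4 the estimated value is 30000 nM, with an expected range from 6000 nM to 100000 nM.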

Compound 4, concentration for 50% growth inhibition: 50000 nM
Estimate against measurement, compound 4: 1.7-fold (0.22 log units) below; low and high end bracket the measured number.
By their numbers in this assay, from the lowest: compound 2; then compound 3; then compounds 1 and 4 (each within the scatter of the next).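

In this assay, for the compounds shown here, 2-bromophenyl in place of 4-chlorobenzyl on a sulfur gives no change at the digits printed from compound 1 to compound 4 (within the scatter) and is the first measured change at this position. With the 2,4-dihydroxyphenyl kept, the two compounds read alike, so this exchange on the sulfur, unlike the exchanges on the double-bonded chain carbon, shows no step beyond the scatter. Open, going by these compounds, is whether the same exchange reads alike with the 2-methoxyphenyl of compound 2, and how an amine or a carboxylic acid on the sulfur substituent would read. No evidence bears on why these two compounds read alike.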